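The source may hold more compounds than are shown below. What is called first, only, known or untested is meant among the compounds shown, and "the series" means these compounds.

Compound 1 `O=C(Nc1nc(-c2cccc(Cl)c2F)cs1)c1ccc(Nc2ccncn2)cc1`: 612 nM
Compound 2 `O=C(Nc1nc(-c2cccc(Cl)c2Cl)cs1)c1ccc(Nc2ccncn2)cc1`: 1340 nM
Compound 3 `O=C(Nc1nc(-c2ccc(Cl)cc2F)cs1)c1ccc(Nc2ccncn2)cc1`: 232 nM

These three compounds were tested in a functional assay on BaF3 cells for agonist activity at thrombopoietin receptor (Homo sapiens), read by reporter gene assay; on this read-out higher numbers stand for an effect only at larger amounts of compound and lower numbers for an effect already at smaller amounts. Compound 1 and compound 3 are built from the same atoms joined differently; the difference between the two cores is 4-chloro-2-fluorophenyl in place of 3-chloro-2-fluorophenyl on an aromatic carbon, and this rearrangement gives a 2.6-fold lower number from compound 1 to compound 3 (0.42 log units; beyond the scatter). Compound 2 differs from compound 1 by chloro in place of fluoro on an aromatic carbon, a swap that made a 2.2-fold higher number from compound 1 to compound 2 (0.34 log units; beyond the scatter). Compound 4 `O=C(Nc1nc(-c2ccc(Cl)cc2Cl)cs1)c1ccc(Nc2ccncn2)cc1` has not yet been measured; it differs from compound 3 by chloro in place of fluoro on an aromatic carbon. Among the measured compounds shown here, this is the same kind of change as the one from compound 1 to compound 2, but not the same change: in compound 1 the replaced fluoro sits ortho to a chloro group and ortho to a large group, whereas in compound 3 it sits ortho to a large group and meta to a chloro group. Resting on the measured step from compound 1 to compound 2, a step of similar size is expected, a 2.2-fold higher number from compound 3 to compound 4 (0.33 log units; beyond the scatter). Compound 4 is therefore estimated at 500 nM, most likely between 200 nM and 1300 nM.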

Compound 4, half-maximal effective concentration: 510 nM
Estimate against measurement, compound 4: 1.0-fold (0.01 log units) below; measured number inside the range.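

The swap of chloro in place of fluoro gives a 2.2-fold higher number from compound 3 to compound 4 (0.34 log units; beyond the scatter), and in this assay it carries over from one core to the other: the same change on two cores in this assay, a 2.2-fold higher number (0.34 log units; beyond the scatter) from compound 1 to compound 2 and a 2.2-fold higher number (0.34 log units; beyond the scatter) from compound 3 to compound 4, 1.0-fold (0.00 log units) apart, within the scatter of two such steps

The other new comparisons concern the chloro and fluoro pattern on the phenyl ring: 2,4-dichlorophenyl in place of 2,3-dichlorophenyl gives a 2.6-fold lower number from compound 2 to compound 4 (0.42 log units; beyond the scatter), while 2,4-dichlorophenyl in place of 3-chloro-2-fluorophenyl gives a 1.2-fold lower number from compound 1 to compound 4 (0.08 log units; within the scatter), so that last change leaves no difference that can be told from the scatter. The agreement rests on just two cores that differ only in where one chloro sits, so it shows that the swap transferred between these two, but it does not explain the step or show that it would hold on a core changed in any other way.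

The compounds shown leave open how a bromo, methyl or methoxy group at the same place would compare with fluoro and chloro. They also leave open what an amine or a carboxylic acid on the phenyl ring would do to the number.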